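The source may report more compounds than this note shows. Statements on the series, on what has been measured and on what is new or still open speak of the compounds shown alone.

Measured in an ADME assay on BCBL1 cells (Homo sapiens) for cytotoxicity, with a stated time of 7 days; on this read-out higher numbers stand for lower toxicity in this test and lower numbers for higher toxicity in this test:
Compound 1 `CCCSc1nc(N)nc2c1ncn2/C=C1/CC1(CO)CO`: > 20000 nM
Compound 2 `CCCOc1nc(N)nc2c1ncn2/C=C1/CC1(CO)CO`: > 20000 nM
Compound 3 `CCCCCCOc1nc(N)nc2c1ncn2/C=C1/CC1(CO)CO`: > 20000 nM

Compound 3 reads > 20000 nM, which is a limit of the assay and not a number. The same holds for the other two entries. Compound 4 `CCCCSc1nc(N)nc2c1ncn2/C=C1/CC1(CO)CO` carries butylsulfanyl in place of hexyloxy on an aromatic carbon.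

Within the data shown here, three measured steps bear on this change. Propoxy in place of propylsulfanyl gives a step that the two limits leave unreadable from compound 1 to compound 2. Hexyloxy in place of propylsulfanyl gives a step that the two limits leave unreadable from compound 1 to compound 3. Lengthening the chain gives a step that the two limits leave unreadable from compound 2 to compound 3. None has a readable size, and all three compounds share (the limit of > 20000 nM in this assay, at which 3 of the 3 values shown sit). No step beyond the usual scatter is therefore expected in this assay, and the estimated step is a number no higher from compound 3 to compound 4 (the limit leaves the size open). The estimate for compound 4 is 20000 nM, with an expected range from 10000 nM to 40000 nM.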

Compound 4, half-maximal cytotoxic concentration: > 20000 nM
Compound 4: only a limit was reported; the forecaster's own chance of this, stated with the estimate: 85%; the middle value lies on the limit itself.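

Compound 4 reads > 20000 nM in this assay and this is a limit of the assay, not a number. Among these compounds, no step from compound 1, compound 2 or compound 3 to compound 4 can be read. The compounds shown leave open how these side chains compare in toxicity, since every value is the same limit: the limit of > 20000 nM in this assay, at which 4 of the 4 values shown sit.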